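Dropping the Pyridin-4-yl Group from Compound 3

A few compounds are considered here, and "the series" means these few. Any claim that something is new, unique, unknown or untested is made for them only; others in the source may bear on it.

Of the compounds shown here, three have been tested in a functional assay on HepG2 cells (Homo sapiens) for cytotoxicity, read by MTT assay, with a stated time of 48 h (a lower number here means a stronger inhibitor, a higher number a weaker inhibitor), so far. Compound 1, `O=S(=O)(CCC(F)(Cl)C(F)(F)Cl)c1nc2ccccc2s1`, gives 4500 nM in this assay. Compound 2, `FC(F)=C(F)CCSc1nnc(S)s1`, reaches only the limit of this assay, reported as > 120000 nM, which is a limit and not a measured number. Compound 3, `O=S(=O)(CCC(F)=C(F)F)c1ncc(-c2ccncc2)s1`, likewise reaches only the limit of this assay, given as > 120000 nM, again a limit rather than a number. So compound 3 stands at the limit of > 120000 nM in this assay, at which 2 of the 3 values shown sit, and gives no number of its own, while only compound 1 gives one.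

Compound 4 is `O=S(=O)(CCC(F)=C(F)F)c1nccs1`. It differs from compound 3 in one place: hydrogen in place of pyridin-4-yl on an aromatic carbon. Among the measured compounds shown here, no pair of measured compounds shows this change, so there is no measured step to weigh it against. Since compound 3 sits at the limit, the step expected here, a number no higher from compound 3 to compound 4 (the limit leaves the size open), is none beyond the usual scatter. Compound 4 is therefore estimated at 120000 nM in this assay, within a range from 30000 nM to 500000 nM, and most likely reported again only as a limit.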

Compound 4, half-maximal inhibitory concentration: > 120000 nM
Compound 4: no number, only a limit (the forecaster's own chance of this, stated with the estimate: 70%); the middle value sits exactly at the limit.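

Among the compounds shown here, no step from compound 3 to compound 4 can be read in this assay, because both compounds give only a limit and no number: the limit of > 120000 nM in this assay, at which 3 of the 4 values shown sit. The compounds shown leave open whether hydrogen in place of pyridin-4-yl on an aromatic carbon changes the reading at all.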